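A few compounds are considered here, and "the series" means these few. Any claim that something is new, unique, unknown or untested is made for them only; others in the source may bear on it.

Compound 1 `Cc1ccc(S(=O)(=O)N2CC(c3nc(-c4cccc(C)c4)no3)C2)cc1` gives > 10000 nM in an assay on HEK293 cells for positive allosteric modulation of metabotropic glutamate receptor 5 (Homo sapiens), read by FLIPR; a higher number here means that more compound is needed for the effect, a lower number that less compound is needed.
Compound 2 `O=C(c1cccc(F)c1)N1CC(c2nc(-c3cccc(Cl)c3)no2)C1` gives > 10000 nM in this assay.
Compound 3 `Cc1cccc(-c2noc(C3CN(C(=O)c4cccc(F)c4)C3)n2)c1` gives > 10000 nM in this assay.

The value of compound 2 in this assay is a limit of the assay, not a number. Compound 1 likewise shows only a limit in this assay. Compound 3 too shows only a limit in this assay. Among the measured compounds shown here, because all three values sit at one limit (the limit of > 10000 nM in this assay, at which 3 of the 3 values shown sit), compound 2 cannot be placed in order relative to compound 1 or compound 3, and the one measured step among them, a step that the two limits leave unreadable from compound 2 to compound 3, cannot be read for size or direction.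

Compound 4 `O=C(N1CCCCC1)N1CC(c2nc(-c3cccc(Cl)c3)no2)C1` differs from compound 2 by piperidin-1-yl in place of 3-fluorophenyl on a carbonyl carbon. For the measured compounds named here, no measured step touches this carbonyl carbon, so nothing measured here speaks for a change in either direction. The expected step that the limit leaves unreadable from compound 2 to compound 4 therefore rests on the limit alone, and the most likely outcome for compound 4 is estimated to be another limit in this assay. Compound 4 is estimated at 15000 nM, with a range from 3000 nM to 60000 nM.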

Compound 4, half-maximal effective concentration: 370 nM
Compound 4: the middle estimate sits 41-fold (1.61 log units) above what was measured, and the stated range ends above it.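

At the carbonyl carbon, piperidin-1-yl in place of 3-fluorophenyl gives an at least 27-fold lower number from compound 2 to compound 4 (1.43 log units; beyond the scatter) in this assay. The earlier compounds could not show that this position responds at all, and compound 4 is the only compound shown with a number rather than a limit of the assay: the limit of > 10000 nM in this assay, at which 3 of the 4 values shown sit. The change swaps an aromatic ring of carbon only for a non-aromatic ring with one hetero atom, while the counted hydrogen-bond donors, acceptors and net charge stay the same.

As far as these compounds go, whether the ring nitrogen or the loss of the aromatic ring carries the step stays open, and a cyclohexyl or morpholin-4-yl group on this carbonyl carbon would bear on that. From the compounds shown here alone, the step from chloro to methyl cannot be read between its two limits, so the role of that group alongside piperidin-1-yl also remains open.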